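The source may report more compounds than this note shows. Statements on the series, on what has been measured and on what is new or still open speak of the compounds shown alone.

Measured so far, in a functional assay on HT-29 cells (Homo sapiens) for antiproliferative activity, read by sulforhodamine B assay, with a stated time of 48 h; a higher number here means a weaker inhibitor, a lower number a stronger inhibitor:

Compound 1, `CN1CCN(c2ccc(S(=O)(=O)Oc3cccc(Cl)c3)cc2)C1=O`, gives 2100 nM.
Compound 2, `CCN1CCN(c2ccc(S(=O)(=O)Oc3cccc(Cl)c3)cc2)C1=O`, gives 6800 nM.
Compound 3, `CCCN1CCN(c2ccc(S(=O)(=O)Oc3ccccc3C)cc2)C1=O`, gives only a limit in this assay, > 100000 nM, and not a number.

Compounds 1 and 2 share one core and differ in a single spot: methyl in place of hydrogen on a saturated chain carbon bound to an amide-type nitrogen in a ring. Going by the values given here, that change produced the step of a 3.2-fold higher number from compound 1 to compound 2 (0.51 log units; beyond the scatter), so adding the one carbon weakened the compound by a modest but real amount. Compound 3 carries a different core, and how the two cores differ is not broken down here; its value sits at the limit of > 100000 nM in this assay, at which 1 of the 3 values shown sits, which means it is known only to be weaker than the assay can resolve.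

Compound 4, `CCCN1CCN(c2ccc(S(=O)(=O)Oc3ccccc3CC)cc2)C1=O`, has not yet been measured in this assay. It is made from compound 3 by methyl in place of hydrogen on a saturated chain carbon bound to an aromatic carbon. Among the compounds with values here, this is the same kind of change as the one between compounds 1 and 2, a methyl in place of a hydrogen, but the place differs: in the earlier pair the carbon sits bound to an amide-type nitrogen in a ring, here it sits bound to an aromatic carbon. Within the data shown here, with only one earlier example, and that one at a different place and on a different core, the size of the new step is uncertain. Still, the earlier step points toward a weaker compound, and compound 3 already stands at the limit. The step from compound 3 to compound 4 is therefore expected to be a step that the limit leaves unreadable from compound 3 to compound 4, most likely leaving compound 4 again beyond what this assay reports as a number. Compound 4 is estimated at 250000 nM, with a plausible range from 100000 nM to 700000 nM.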

Compound 4, half-maximal inhibitory concentration: > 100000 nM
Compound 4: only a limit was reported; the forecaster's own chance of this, stated with the estimate: 85%; the middle value does not contradict the limit.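

In this assay compound 4 gives only a limit, > 100000 nM, and not a number. Going by these compounds alone, compound 3 is also reported only as a limit, so no step from compound 3 to compound 4 can be read: the limit of > 100000 nM in this assay, at which 2 of the 4 values shown sit. The compounds shown leave open whether the change from 2-methylphenyl to 2-ethylphenyl alters activity at all, and in which direction.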